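N-substituent variation on the anilino nitrogen: notes

The source may hold more compounds than are shown below. What is called first, only, known or untested is meant among the compounds shown, and "the series" means these compounds.

Measured so far:
compound 1 `Cc1nc2ccc(CN(CC#N)c3ccc(C(=O)N[C@@H](CCC(=O)O)C(=O)O)c(F)c3)cc2c(=O)[nH]1` — 170 nM
compound 2 `Cc1nc2ccc(CN(CC(N)=O)c3ccc(C(=O)N[C@@H](CCC(=O)O)C(=O)O)c(F)c3)cc2c(=O)[nH]1` — 1340 nM
compound 3 `C=CCN(Cc1ccc2nc(C)[nH]c(=O)c2c1)c1ccc(C(=O)N[C@@H](CCC(=O)O)C(=O)O)c(F)c1` — 76 nM

All three were run in an assay on isolated protein for inhibition of Thymidylate synthase (Mus musculus); a lower number here means a stronger inhibitor, a higher number a weaker inhibitor. Compound 3 holds the lowest number of the three; compound 1 sits nearest, and compound 2 furthest. The two steps from compound 1 show the substituent on the saturated chain carbon bound to the nitrogen on the aromatic ring is consequential: a 7.9-fold higher number from compound 1 to compound 2 (0.90 log units; beyond the scatter), while a 2.2-fold lower number from compound 1 to compound 3 (0.35 log units; beyond the scatter). Between the extremes, an 18-fold lower number from compound 2 to compound 3 (1.25 log units; beyond the scatter).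

Compound 4 `Cc1nc2ccc(CN(C)c3ccc(C(=O)N[C@@H](CCC(=O)O)C(=O)O)c(F)c3)cc2c(=O)[nH]1` is not yet measured. It differs from compound 3 thus: hydrogen in place of vinyl on a saturated chain carbon bound to a nitrogen on an aromatic ring. Among the measured compounds shown here, no measured step removes a substituent from that chain carbon outright; the steps in hand all swap one group for another, and the spread among them is wide, with compound 2 the outlier. The vinyl of compound 3 gave the lowest number seen, so the loss of it is expected to raise the number in this assay by a modest step rather than leave it unchanged. The expected step is a 2.6-fold higher number from compound 3 to compound 4 (0.42 log units; beyond the scatter). Compound 4 is estimated at 200 nM, within a range of 60 nM to 700 nM.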

Compound 4, half-maximal inhibitory concentration: 120 nM
Beside the measured number, compound 4's estimate is 1.7-fold (0.22 log units) above it; measured number inside the range.
By their numbers in this assay, from the lowest: compounds 3, 4 and 1 (each within the scatter of the next, the first and the last beyond it); then compound 2.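

Going from allyl to methyl in this assay gives a 1.6-fold higher number from compound 3 to compound 4 (0.20 log units; within the scatter) and so the vinyl on the saturated chain carbon bound to a nitrogen on an aromatic ring cannot be told apart from hydrogen there. Hydrogen in place of cyano reads the same way, with a 1.4-fold lower number from compound 1 to compound 4 (0.15 log units; within the scatter) as its step, whereas hydrogen in place of carbamoyl gives an 11-fold lower number from compound 2 to compound 4 (1.05 log units; beyond the scatter) as the one large change, so among the groups shown only carbamoyl separates clearly from the plain methyl. Nothing measured bears on why carbamoyl stands apart from the other groups at this position.

From the compounds shown here alone, whether the large step belongs to carbamoyl alone stays open: a hydroxyl, an amine or a carboxylic acid on that chain carbon would show whether other groups of this kind behave as carbamoyl does. Also open, going by these compounds, is how much length the position accepts, as a longer chain such as propyl or butyl could either stay level with methyl and allyl or move away from them.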